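The source may report more compounds than this note shows. Statements on the series, on what has been measured and on what is new or still open speak of the compounds shown alone.

Two compounds built on the same chain, which ends in a trifluoromethyl group bearing two hydroxyls, have been measured so far. Compound 1 `O=C(CCCCCCNC(=O)C(O)(O)C(F)(F)F)Nc1cccc(Br)c1` carries a 3-bromophenyl group on its amide nitrogen, while compound 2 `O=C(CCCCCCNC(=O)C(O)(O)C(F)(F)F)Nc1nc2ccc(Br)cc2s1` carries a different aromatic group in the same position. In a functional assay on HCT-116 cells (Homo sapiens) for inhibition, read by colorimetric assay, with a stated time of 3 days (on this read-out lower numbers stand for stronger inhibition and higher numbers for weaker inhibition), compound 1 gives 3060 nM, the lower of the two numbers seen. In this assay compound 2 gives 10300 nM, which stands clearly apart from compound 1, beyond the usual scatter. Compound 3 `O=C(CCCCCCNC(=O)C(O)(O)C(F)(F)F)Nc1ccccc1` has not been measured; it differs from compound 1 in a single place, (hydrogen in place of bromo on an aromatic carbon), the bromo leaving an aromatic carbon of the six-membered aromatic ring of carbon only, meta to a large group. Among the measured compounds shown here, no pair of measured compounds differs in exactly one place, so there is no measured step to lean on. Removing the bromo is expected to cost a little inhibition, a step from compound 1 to compound 3 of a 1.8-fold higher number from compound 1 to compound 3 (0.25 log units; within the scatter), close to the edge of the scatter. Compound 3 is therefore expected to give 5500 nM, within a range of 2200 nM to 14000 nM.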

Compound 3, half-maximal inhibitory concentration: 9140 nM
For compound 3 the middle estimate is 1.7-fold (0.22 log units) below the measured one; the measured number falls inside the stated range.
By their numbers in this assay, from the lowest: compound 1; then compounds 3 and 2 (each within the scatter of the next).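

Among the compounds shown here, compound 1 and compound 3 form the first pair here that differs in one place only, and in this assay the change gives a clear step (a 3.0-fold higher number from compound 1 to compound 3 (0.48 log units; beyond the scatter)). Removing one bromine atom, with no hydrogen-bond donor, acceptor or net charge involved in the swap, moves the number beyond the usual scatter, so this place on the aromatic ring does respond to what sits on it, and the bromo goes with stronger inhibition than hydrogen. Nothing at hand says what the bromo does to produce this difference.

From the compounds shown here alone, whether this is particular to the bromo or would also appear with another group in the same place stays open; a chloro, a methyl, a methoxy, an amine or a carboxylic acid there would each give a further comparison with hydrogen. Also open, going by these compounds, is whether removing the bromo from compound 2 would give a step of similar size, or whether this step belongs to the 3-bromophenyl group alone.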